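Swapping the Reactive Amide on a Shared Core

The compounds below may be only part of what the source reports. "The series", "measured", "known", "first", "only" and "open" are said of these compounds alone.

Of the compounds shown here, three have been measured in a functional assay on PC-3 cells (Homo sapiens) for antiproliferative activity, read by MTT assay, with a stated time of 72 h; on this read-out lower numbers stand for stronger inhibition and higher numbers for weaker inhibition. Compound 1 `C=C(C)C(=O)Nc1cc2c(N3CCc4ccccc43)ncnc2cc1OC` gives 4830 nM. Compound 2 `C=CC(=O)Nc1cc2c(N3CCc4ccccc43)ncnc2cc1O[C@@H]1CCOC1` gives 2710 nM, and compound 3 `CC(C)/C=C/C(=O)Nc1cc2c(N3CCCc4ccccc43)ncnc2cc1O[C@@H]1CCOC1` gives 8510 nM. Compound 1 sits between the other two values, and its gaps to compound 2 and to compound 3 are both within the usual scatter, so the three read as roughly equal. Compound 4 `COc1cc2ncnc(N3CCc4ccccc43)c2cc1NC(=O)/C=C/CN(C)C` is not yet measured. It differs from compound 1 in one place: 3-(dimethylamino)prop-1-en-1-yl in place of 1-methylethenyl on a carbonyl carbon. Among the compounds with values here, no measured pair shows this exact change, so the expectation rests on the shared amide attachment alone. The step of a 1.9-fold lower number from compound 1 to compound 4 (0.29 log units; within the scatter) is expected to be modest, toward a lower number, near the edge of the scatter. Compound 4 is expected at 2500 nM, with a likely range from 800 nM to 8000 nM.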

Compound 4, half-maximal inhibitory concentration: 2190 nM
Compound 4: the middle estimate sits 1.1-fold (0.06 log units) above what was measured, and the stated range covers the measured number.
By their numbers in this assay, from the lowest: compounds 4, 2, 1 and 3 (each within the scatter of the next, the first and the last beyond it).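

In this assay, 3-(dimethylamino)prop-1-en-1-yl in place of 1-methylethenyl on a carbonyl carbon gives a modest step (a 2.2-fold lower number from compound 1 to compound 4 (0.34 log units; beyond the scatter)). Within the data shown here, this is the first change in one place that can be read here, and it shows that this amide position tolerates the larger amine-bearing group with no loss of activity. Nothing available explains the step.

As far as these compounds go, what a morpholine or a piperidine in place of the dimethylamino group would give stays open. So does whether a plain butenyl chain without any amine would behave the same way.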